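The source may hold more compounds than are shown below. What is called first, only, known or untested is meant among the compounds shown, and "the series" means these compounds.

In a functional assay on HCT-116 cells (Homo sapiens) for inhibition, read by CCK-8 assay, with a stated time of 48 h (on this read-out higher numbers stand for weaker inhibition and lower numbers for stronger inhibition), compound 3 `COc1ccc(CN(C(=O)CSC(=S)N2CCCC2)c2cc(OC)c(OC)c(OC)c2)cc1` gives 4970 nM. This lies within the scatter of both neighbours: compound 1 `COc1ccc(CN(C(=O)CSc2nc3ccccc3o2)c2cc(OC)c(OC)c(OC)c2)cc1` at 3280 nM and compound 2 `COc1ccc(CN(C(=O)CSC(=S)N2CCN(C)CC2)c2cc(OC)c(OC)c(OC)c2)cc1` at 2640 nM. Among the measured compounds shown here, the series so far therefore reads as one flat level.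

The next exchange leads to compound 4 `CCN1CCN(CC(=O)N(Cc2ccc(OC)cc2)c2cc(OC)c(OC)c(OC)c2)CC1`: a group of 8 heavy atoms (6 carbon, 2 nitrogen; one six-membered non-aromatic ring with 2 hetero atoms) in place of a group of 8 heavy atoms (5 carbon, 1 nitrogen, 2 sulfur; one five-membered non-aromatic ring with 1 hetero atom), on a saturated chain carbon bound to a carbonyl carbon. The rest of the structure stays the same.

For the measured compounds named here, three measured steps bear on this: a 1.2-fold lower number from compound 1 to compound 2 (0.09 log units; within the scatter), a 1.5-fold higher number from compound 1 to compound 3 (0.18 log units; within the scatter) and a 1.9-fold higher number from compound 2 to compound 3 (0.27 log units; within the scatter). All three stay within the scatter, and the last is the closest comparison, as it exchanges pyrrolidin-1-yl and 4-methylpiperazin-1-yl on a thiocarbonyl carbon. None of them tests the exchange itself, however. Going by the values given here, every measured compound keeps sulfur in this group, compound 4 has none, and no measured compound carries 4-ethylpiperazin-1-yl.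

On the strength of a 1.9-fold higher number from compound 2 to compound 3 (0.27 log units; within the scatter), and with compound 2 at 2640 nM as the nearest six-membered ring example, no step beyond the scatter is expected in this assay, in either direction. The expected change is a 1.4-fold lower number from compound 3 to compound 4 (0.15 log units; within the scatter). The untested loss of sulfur keeps the range wide. Compound 4 is estimated at 3500 nM, with an expected range of 1300 nM to 9000 nM.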

Compound 4, half-maximal inhibitory concentration: > 20000 nM
Compound 4: only a limit was reported; the forecaster's own chance of this, stated with the estimate: 3%; at least 5.7-fold (0.75 log units) between middle value and limit.
By their numbers in this assay, from the lowest: compounds 2, 1 and 3 (each within the scatter of the next). At a limit, above all of these: compound 4.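

In this assay compound 4 stands at a limit and not at a number: the limit of > 20000 nM in this assay, at which 1 of the 4 values shown sits.

The sulfur-bearing groups on this saturated chain carbon bound to a carbonyl carbon gave one flat level, but this position does respond to change: 4-ethylpiperazin-1-yl gives an at least 4.0-fold higher number from compound 3 to compound 4 (0.60 log units; beyond the scatter), along with an at least 7.5-fold higher number from compound 2 to compound 4 (0.87 log units; beyond the scatter) and an at least 6.0-fold higher number from compound 1 to compound 4 (0.78 log units; beyond the scatter), all three beyond the scatter. Compound 2 and compound 4 both carry a six-membered non-aromatic ring with 2 hetero atoms in this group, and the sulfur atoms are absent only from compound 4, so ring type alone does not track the shift among these compounds.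

The limit leaves the true size of these steps undefined, and the compounds shown do not separate the loss of the sulfur atoms from the change of methyl to ethyl on the piperazine ring. 4-Methylpiperazin-1-yl or morpholin-4-yl set directly on the same chain carbon, or a (2-dimethylaminoethyl)sulfanyl group there, would help to divide these two contributions.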